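The source may report more compounds than this note shows. Statements on the series, on what has been measured and on what is new or still open speak of the compounds shown alone.

Compound 1 `Fc1ccc(-c2nc3cnc(Nc4ccccn4)cc3[nH]2)cc1C(F)(F)F`: in a physicochemical assay for solubility, using the shake flask method, in simulated intestinal fluid, measured as kinetic solubility, with a stated time of 20 h, at pH 6.5 (on this read-out lower numbers stand for lower solubility and higher numbers for higher solubility), compound 1 gives >= 50000 nM; this is a limit of the assay, not a number.
Compound 2 `Fc1ccc(-c2nc3cnc(Nc4ccccn4)cc3[nH]2)cc1F`: in this assay compound 2 gives >= 50000 nM; this too is a limit of the assay.
Compound 3 `Fc1ccc(-c2nc3cnc(Nc4ccc(C(F)(F)F)cn4)cc3[nH]2)cc1F`: in this assay compound 3 gives >= 50000 nM; again a limit of the assay.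

Compound 2 therefore stands at the upper edge of what this assay can report, and so do the two other compounds, as the limit of >= 50000 nM in this assay, at which 3 of the 3 values shown sit, shows. Compound 4 `Fc1ccnc(Nc2cc3[nH]c(-c4ccc(F)c(F)c4)nc3cn2)c1` differs from compound 2 in one place: fluoro in place of hydrogen on an aromatic carbon. Within the data shown here, two measured steps bear on such a single change on this part of the molecule, a step that the two limits leave unreadable from compound 1 to compound 2 and a step that the two limits leave unreadable from compound 2 to compound 3; neither has a readable size, because the limit of >= 50000 nM in this assay, at which 3 of the 3 values shown sit, caps every value. No step beyond the usual scatter can be read from them in either direction. For compound 4 in this assay the expected value is 50000 nM, within a range from 25000 nM to 100000 nM. The step from compound 2 to compound 4 that this estimate means is a number no higher from compound 2 to compound 4 (the limit leaves the size open).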

Compound 4, solubility: >= 50000 nM
Compound 4: only a limit was reported; the forecaster's own chance of this, stated with the estimate: 80%; the middle value lies on the limit itself.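

No step can be read from compound 2 to compound 4, because both compounds give only a limit and not a number: the limit of >= 50000 nM in this assay, at which 4 of the 4 values shown sit. The compounds shown leave open how far any of the true values in this assay lie beyond that limit, and so whether fluoro in place of hydrogen changes the read-out at all.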